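The source may hold more compounds than are shown below. What is called first, only, known or untested is meant among the compounds shown, and "the series" means these compounds.

Measured compounds:
compound 1, `Cc1ccc(-c2csc(NC(=O)COc3ccccc3)n2)cc1` — 54500 nM
compound 2, `O=C(COc1ccccc1)Nc1nc(-c2ccc(Br)cc2)cs1` — 37100 nM
compound 3, `Cc1ccc(OCC(=O)Nc2nc(-c3ccc(C)cc3)cs2)cc1` — 37100 nM

In a functional assay on MDA-MB-468 cells (Homo sapiens) for cytotoxicity, read by trypan blue exclusion, with a stated time of 48 h (on this read-out lower numbers stand for stronger inhibition and higher numbers for weaker inhibition), compound 1 gives 54500 nM. Compound 2 gives 37100 nM and compound 3 gives 37100 nM; these two stand level at the digits recorded, and together they hold the lowest of the three numbers, while all three values lie within the usual scatter of one another, so no order among them can be read from these data.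

Compound 4, `Cc1ccc(OCC(=O)Nc2nc(-c3ccc(Br)cc3)cs2)cc1`, has not yet been measured in this assay. It differs from compound 3 by bromo in place of methyl on an aromatic carbon. The same change has already been made once, from compound 1 to compound 2, as bromo in place of methyl on an aromatic carbon, where it gave a 1.5-fold lower number from compound 1 to compound 2 (0.17 log units; within the scatter). The two cores on which the change is made differ by methyl in place of hydrogen on an aromatic carbon. The place of the change is described in the same words in both cases, so this is taken as the same change on a slightly different core.

The expectation for compound 4 rests on that single earlier instance: because a 1.5-fold lower number from compound 1 to compound 2 (0.17 log units; within the scatter) stayed within the scatter, the step from compound 3 to compound 4 is expected to be of similar size, about a 1.2-fold lower number from compound 3 to compound 4 (0.09 log units; within the scatter). On that basis compound 4 is estimated at 30000 nM in this assay, with a range of 15000 nM to 60000 nM expected; a single precedent leaves this estimate loosely held.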

Compound 4, half-maximal inhibitory concentration: 44500 nM
The estimate for compound 4 lay 1.5-fold (0.17 log units) below the measured number; the range from low to high includes it.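

In this assay, going from 4-methylphenyl to 4-bromophenyl gives a 1.2-fold higher number from compound 3 to compound 4 (0.08 log units; within the scatter), and the two instances of this change do not differ by more than the scatter allows: the same change on two cores in this assay, a 1.5-fold lower number (0.17 log units; within the scatter) from compound 1 to compound 2 and a 1.2-fold higher number (0.08 log units; within the scatter) from compound 3 to compound 4, 1.8-fold (0.25 log units) apart, within the scatter of two such steps

Adding methyl on an aromatic carbon of the other ring gives a 1.2-fold higher number from compound 2 to compound 4 (0.08 log units; within the scatter), and this change reads the same way on its two cores: the same change on two cores in this assay, a 1.5-fold lower number (0.17 log units; within the scatter) from compound 1 to compound 3 and a 1.2-fold higher number (0.08 log units; within the scatter) from compound 2 to compound 4, 1.8-fold (0.25 log units) apart, within the scatter of two such steps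

Every step among these four compounds lies within the scatter, so the agreement shows only that neither change has a size that can be told from repeated-measurement noise here; it does not show that either change carries a real effect from one core to another, nor that the two changes are independent of each other.

On these data alone, whether an amine or a carboxylic acid in place of the bromo, on the ring that carries it in compound 4, would give a step beyond the scatter remains open. Also open, as far as these compounds go, is whether a longer chain in place of the methyl on either ring would move the number away from the level of compound 4 at 44500 nM.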